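Clearance Across a Tricyclic Series: Oxetane to Hydroxymethyl

This account rests on a few compounds, and the source may have more. Where it says the series, first, only, none or still open, it means among the compounds named here.

Measured compounds:
- compound 1, `CC#Cc1cncc(-c2ccc3c(c2)[C@@]2(COC(N)=N2)c2cc(Cl)ncc2O3)c1`: 27 mL.min-1.g-1
- compound 2, `CC1(C#Cc2cncc(-c3ccc4c(c3)[C@@]3(COC(N)=N3)c3cc(C5=CCOCC5)ncc3O4)c2)COC1`: 420 mL.min-1.g-1
- compound 3, `COc1cc2c(cn1)Oc1ccc(NC(=O)c3ccc(Cl)cn3)cc1[C@@]21COC(N)=N1`: < 14 mL.min-1.g-1

Three compounds sharing a fused tricyclic core carrying a cyclic amidine have been run in an ADME assay on microsomes from liver (Homo sapiens) for metabolic stability, read by LC-MS, using NADPH, with a stated time of 30 min, tested at 1 uM; a lower number here means slower removal, a higher number faster removal of the compound. Compound 1 gives 27 mL.min-1.g-1. Compound 2 gives 420 mL.min-1.g-1, the highest of the two plain numbers, and sits well beyond the scatter from compound 1. Compound 3 returns only a limit of the assay, < 14 mL.min-1.g-1, as noted in the limit of < 14 mL.min-1.g-1 in this assay, at which 1 of the 3 values shown sits.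

Compound 4, `NC1=N[C@@]2(CO1)c1cc(-c3cncc(C#CCO)c3)ccc1Oc1cnc(C3=CCOCC3)cc12`, has not yet been measured in this assay. It differs from compound 2 in one place: hydroxymethyl in place of 3-methyloxetan-3-yl on a triple-bonded carbon.

For the measured compounds named here, no step between measured compounds isolates this change, so its size can only be guessed. Given that compound 2 stands at 420 mL.min-1.g-1, the starting point is high, and a moderate fall in this assay is expected for compound 4, though a result within the scatter of compound 2 would not surprise. The expected step from compound 2 to compound 4 is a 2.8-fold lower number from compound 2 to compound 4 (0.45 log units; beyond the scatter). Compound 4 is therefore estimated at 150 mL.min-1.g-1, with a range of 50 mL.min-1.g-1 to 400 mL.min-1.g-1.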

Compound 4, intrinsic clearance in microsomes: 84 mL.min-1.g-1
For compound 4 the middle estimate is 1.8-fold (0.25 log units) above the measured one, and the stated range covers the measured number.
By their numbers in this assay, from the lowest: compound 1; then compound 4; then compound 2. At a limit, below all of these: compound 3.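

Swapping 3-methyloxetan-3-yl for hydroxymethyl on a triple-bonded carbon gives the first single-place comparison in this set. In this assay it produces a 5.0-fold lower number from compound 2 to compound 4 (0.70 log units; beyond the scatter), so the group at this position can shift the intrinsic clearance by more than the usual scatter of repeated measurements. This rests on one pair of compounds, and nothing measured here accounts for the size or direction of the step.

The compounds shown leave open whether aminomethyl, methoxymethyl or a longer hydroxyalkyl chain on the same triple-bonded carbon would give a higher or lower number. They also leave open whether the swap from 3-methyloxetan-3-yl to hydroxymethyl would give a step of similar size with a chlorine or a methoxy group in place of the ring that compound 2 and compound 4 share.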